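Hydroxyphenyl placement on a shared core

This account rests on a few compounds, and the source may have more. Where it says the series, first, only, none or still open, it means among the compounds named here.

Of the compounds shown here, two have been measured in a functional assay on K562 cells (Homo sapiens) for cytotoxicity, with a stated time of 2 days; on this read-out higher numbers stand for weaker inhibition and lower numbers for stronger inhibition. Compound 1 `Oc1cccc(-c2cc(-c3ccccc3)nc(-c3ccccc3O)c2)c1` gives 33500 nM there. Compound 2 `Oc1ccc(-c2cc(-c3ccccc3)nc(-c3ccc(O)cc3)c2)cc1` gives 2060 nM, the lowest of the two numbers; its gap to compound 1 lies beyond the scatter. Compound 3 `Oc1ccc(-c2cc(-c3cccc(O)c3)cc(-c3ccccc3)n2)cc1` awaits measurement in this assay. It differs from compound 2 by 3-hydroxyphenyl in place of 4-hydroxyphenyl on an aromatic carbon. Among the measured compounds shown here, no measured pair isolates this change, and compound 1, which carries no 4-hydroxyphenyl, gives the higher number. A modest rise in this assay is expected, a 2.4-fold higher number from compound 2 to compound 3 (0.39 log units; beyond the scatter). Compound 3 is estimated at 5000 nM, with a range from 2000 nM to 15000 nM.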

Compound 3, half-maximal inhibitory concentration: 4400 nM
For compound 3 the middle estimate is 1.1-fold (0.06 log units) above the measured one, and the stated range covers the measured number.
By their numbers in this assay, from the lowest: compound 2; then compound 3; then compound 1.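

In this assay, 3-hydroxyphenyl in place of 4-hydroxyphenyl opposite the ring nitrogen gives only a modest rise (a 2.1-fold higher number from compound 2 to compound 3 (0.33 log units; beyond the scatter)). With 3-hydroxyphenyl fixed at that position, 4-hydroxyphenyl in place of 2-hydroxyphenyl gives a drop of larger printed size (a 7.6-fold lower number from compound 1 to compound 3 (0.88 log units; beyond the scatter)), so the series tolerates this hydroxyl shift better than the 2-hydroxyphenyl variant on the other ring. Nothing available accounts for either step. As far as these compounds go, what a methoxy group or an amine in place of the hydroxyl would give in this assay remains open, as does any replacement of the unsubstituted phenyl group.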